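Methylating a Phenol Hydroxyl in Two Related Series

A few compounds are considered here, and "the series" means these few. Any claim that something is new, unique, unknown or untested is made for them only; others in the source may bear on it.

Measured compounds:
Compound 1, `O=C(Nc1cccc(-n2cc(-c3ccncc3)c(-c3cc(O)cc(Cl)c3)n2)c1)Nc1ccc(Cl)c(Cl)c1`, gives 3.96%.
Compound 2, `COc1cc(Cl)cc(-c2nn(-c3cccc(NC(=O)Nc4ccc(Cl)c(Cl)c4)c3)cc2-c2ccncc2)c1`, gives 11.4%.
Compound 3, `O=C(Nc1cccc(-n2cc(-c3ccncc3)c(-c3cc(O)cc(Cl)c3)n2)c1)c1cc(C(F)(F)F)cc(C(F)(F)F)c1`, gives 27.3%.

All three numbers come from a functional assay on A549 cells (Homo sapiens) for inhibition, read by sulforhodamine B assay, with a stated time of 48 h, tested at 10 uM; a higher number here means a weaker effect of the compound at the concentration tested, a lower number a stronger effect. Compound 1 and compound 2 share a urea-linked core and differ only by methyl in place of hydrogen on an oxygen on an aromatic ring. That change gave a number 7.4 percentage points higher from compound 1 to compound 2 (within the scatter), so the two numbers cannot be told apart. Compound 3 carries an amide with two trifluoromethyl groups in place of the urea; the difference between its core and that of compound 1 is not broken down here. In this assay compound 3 stands highest of the three, and its gaps to compound 2 and to compound 1 both lie beyond the usual scatter.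

Compound 4, `COc1cc(Cl)cc(-c2nn(-c3cccc(NC(=O)c4cc(C(F)(F)F)cc(C(F)(F)F)c4)c3)cc2-c2ccncc2)c1`, has not yet been measured. It differs from compound 3 by methyl in place of hydrogen on an oxygen on an aromatic ring. The surroundings of the place are described in the same words as for the change from compound 1 to compound 2, so this is the same change, now made on the amide core rather than the urea core. The step from compound 3 to compound 4 is expected to resemble the earlier one, resting on a number 7.4 percentage points higher from compound 1 to compound 2 (within the scatter), and is estimated as a number 6.7 percentage points higher from compound 3 to compound 4 (within the scatter). Compound 4 is therefore expected to give about 34% in this assay, most likely between 15% and 55%.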

Compound 4, a percentage reported as activity, at one concentration (the size of the read-out at that concentration, not a potency): 43.5%
Compound 4: middle estimate off by 9.5 percentage points, on the low side; the range from low to high includes it.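

Changing 3-chloro-5-hydroxyphenyl to 3-chloro-5-methoxyphenyl on the amide core gave, in this assay, a number 16.2 percentage points higher from compound 3 to compound 4 (beyond the scatter), so on this core the methoxy compound has the weaker effect at the concentration tested. The same change on the urea core could not be separated from the usual scatter, yet the two steps themselves cannot be told apart, so the data give no sign that the core alters what this change does: the same change on two cores in this assay, a number 7.4 percentage points higher (within the scatter) from compound 1 to compound 2 and a number 16.2 percentage points higher (beyond the scatter) from compound 3 to compound 4, 8.8 percentage points apart, within the scatter of two such steps. Among the compounds shown here, this is a comparison of only two pairs, each read at a single concentration, so it neither proves that the two steps are equal in size nor shows that the change would behave alike on any further core, and it says nothing about why the numbers behave as they do.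

With only the hydroxy and methoxy forms shown, it remains open how a longer chain such as ethoxy, or an amine in the same place, would read in this assay. Also open, as far as these compounds go, is how the hydroxy and methoxy compounds would compare across a range of concentrations, since one concentration gives the size of an effect and not a potency.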